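Methylamino for hydroxy on a fused two-ring core

The compounds below may be only part of what the source reports. "The series", "measured", "known", "first", "only" and "open" are said of these compounds alone.

Compound 1 `CCc1cccc2c1nc(-c1c(F)cccc1F)n2Cc1c(F)cccc1F` and compound 2 `Oc1cccc2c1nc(-c1c(F)cccc1F)n2Cc1c(F)cccc1F` differ at a single aromatic carbon. In a toxicity assay on CCRF-CEM cells (Homo sapiens) for cytotoxicity (a lower number here means that less compound is tolerated, a higher number that more compound is tolerated), compound 1 gives 26.1 uM. Compound 2, by contrast, gives only a limit of this assay, > 100 uM, so no number is known for it. Of the two values shown, compound 2 thus sits at the limit described by the limit of > 100 uM in this assay, at which 1 of the 2 values shown sits, while compound 1 sits below it. Within the data shown here, the one measured step, an at least 3.8-fold higher number from compound 1 to compound 2 (0.58 log units; beyond the scatter), put hydroxy in place of ethyl on an aromatic carbon.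

Compound 3 `CNc1cccc2c1nc(-c1c(F)cccc1F)n2Cc1c(F)cccc1F` has not yet been measured. It differs from compound 2 as follows: methylamino in place of hydroxy on an aromatic carbon. Among the measured compounds shown here, no measured step exchanges hydroxy for methylamino, so the step from compound 1 to compound 2 bears on it only indirectly, by showing how far a change at this carbon can move the number. Since compound 2 already sits at the limit in this assay, compound 3 is expected to remain near that limit, with a step of an at least 1.2-fold lower number from compound 2 to compound 3 (0.09 log units; that floor lies within the scatter). Compound 3 is therefore estimated at 80 uM, between 30 uM and 200 uM.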

Compound 3, half-maximal toxic concentration: 27.2 uM
The estimate for compound 3 lay 2.9-fold (0.47 log units) above the measured number; the measured number lies below the stated range.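

Methylamino in place of hydroxy at this aromatic carbon gives an at least 3.6-fold lower number from compound 2 to compound 3 (0.56 log units; beyond the scatter) in this assay, even though the two groups carry the same counts of hydrogen-bond donors and acceptors, so those counts alone do not set the number here. Methylamino in place of ethyl gives a 1.0-fold higher number from compound 1 to compound 3 (0.02 log units; within the scatter), so in this assay methylamino and ethyl cannot be told apart at this position, although one of them carries a donor and the other does not. Among the compounds shown, hydroxy therefore stands apart, and compound 2 alone sits at a limit of the assay rather than at a number: the limit of > 100 uM in this assay, at which 1 of the 3 values shown sits.

As far as these compounds go, the true size of the step from hydroxy remains unknown, since the limit of compound 2 sets only a floor on it. From the compounds shown here alone, it also remains open whether the separation belongs to hydroxy alone or extends to other groups at this carbon, and a methoxy group or a primary amine there would help to distinguish these readings.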